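The source may report more compounds than this note shows. Statements on the series, on what has been measured and on what is new or still open speak of the compounds shown alone.

Measured so far:
compound 1 `Fc1ccc(-c2nc3ncccn3c2NC2CCCCC2)cc1`: 100000 nM
compound 2 `Oc1ccccc1-c1nc2ncccn2c1NC1CCCCC1`: > 100000 nM

Both compounds were tested in a toxicity assay on A549 cells (Homo sapiens) for cytotoxicity, read by luminescence and CellTiter-Glo, with a stated time of 48 h; on this read-out lower numbers stand for higher toxicity in this test and higher numbers for lower toxicity in this test. Compound 2 gives > 100000 nM, which is a limit of the assay and not a number. Its standing is therefore known only from this limit: the limit of > 100000 nM in this assay, at which 1 of the 2 values shown sits.

Compound 3 `Cc1cc(Br)ccc1-c1nc2ncccn2c1NC1CCCCC1` is the next to be read in this assay. It keeps the core and the cyclohexylamino group of compound 2 and changes only the aryl group on the aromatic carbon: 4-bromo-2-methylphenyl in place of 2-hydroxyphenyl on an aromatic carbon.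

Among the measured compounds shown here, one measured step bears on this place: a number no lower from compound 1 to compound 2 (the limit leaves the size open). It gives a direction but no size, so it cannot be scaled to the new group. Like compound 3, compound 1 has a halogen-bearing phenyl group here, and compound 1 gives 100000 nM. A modest move to a lower number is therefore expected, although another limit-only result is quite possible.

The expected change is an at least 1.4-fold lower number from compound 2 to compound 3 (0.15 log units; that floor lies within the scatter). For compound 3 the estimated value is 70000 nM, with an expected range from 20000 nM to 100000 nM.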

Compound 3, half-maximal cytotoxic concentration: 45000 nM
Beside the measured number, compound 3's estimate is 1.6-fold (0.19 log units) above it, within the range that was stated.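

In this assay, among the compounds shown here, the aryl group on the aromatic carbon now gives a first step of readable size: 4-bromo-2-methylphenyl in place of 4-fluorophenyl yields a 2.2-fold lower number from compound 1 to compound 3 (0.35 log units; beyond the scatter), so a change confined to this place can move the number beyond the scatter, towards higher toxicity in this test. Against the 2-hydroxyphenyl group, the same 4-bromo-2-methylphenyl group gives an at least 2.2-fold lower number from compound 2 to compound 3 (0.34 log units; beyond the scatter), which replaces the earlier direction-only reading at this position with a floor on the size of the step. Compound 2 still stands only at a limit of the assay, so this step has no upper bound: the limit of > 100000 nM in this assay, at which 1 of the 3 values shown sits.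

The 4-bromo-2-methylphenyl group differs from 4-fluorophenyl in both its halogen and its methyl group, so the shown compounds do not separate the share of each in the step, and a 4-bromophenyl or a 2-methylphenyl group would bear directly on that question. Also open is how this read-out responds to a carboxylic acid on the aryl group, or to an open-chain amine in place of the cyclohexylamino group, which all the compounds shown keep.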